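A few compounds are considered here, and "the series" means these few. Any claim that something is new, unique, unknown or untested is made for them only; others in the source may bear on it.

Values in a functional assay on CT26 cells (Mus musculus) for antiproliferative activity, read by CCK-8 assay, with a stated time of 48 h; a lower number here means a stronger inhibitor, a higher number a weaker inhibitor:
- Compound 1 `O=C(CCCCCCC(=O)NCCNc1nonc1/C(=N/O)Nc1ccc(F)c(Br)c1)NO`: 97500 nM
- Compound 2 `O=C(CCCCC(=O)NCCNc1nonc1/C(=N/O)Nc1ccc(F)c(Br)c1)NO`: > 100000 nM, a limit of the assay and not a number
- Compound 3 `O=C(CCCCCC(=O)NCCNc1nonc1/C(=N/O)Nc1ccc(F)c(Br)c1)NO`: 95500 nM

Compound 3 shares its place on the scale with compound 1, the two lying within the scatter of each other. The gap reads a 1.0-fold lower number from compound 1 to compound 3 (0.01 log units; within the scatter).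

Compound 4 `O=C(CCCC(=O)NCCNc1nonc1/C(=N/O)Nc1ccc(F)c(Br)c1)NO` carries hydroxycarbamoyl in place of 2-(hydroxycarbamoyl)ethyl on a saturated chain carbon, three bonds along the chain from a carbonyl carbon.

The same swap, four bonds along the chain from a carbonyl carbon, gave an at least 1.0-fold higher number from compound 1 to compound 2 (0.01 log units; that floor lies within the scatter). The nearest chain change gave an at least 1.0-fold lower number from compound 2 to compound 3 (0.01 log units; that floor lies within the scatter). Neither shows a step beyond the scatter, and a reading of only a limit is quite possible here. The expected step is a 1.2-fold higher number from compound 3 to compound 4 (0.06 log units; within the scatter), so none beyond the scatter is expected. The estimate for compound 4 is 110000 nM, with an expected range of 60000 nM to 200000 nM.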

Compound 4, half-maximal inhibitory concentration: > 100000 nM
Compound 4 ended at the assay's limit (the forecaster's own chance of this, stated with the estimate: 70%); the middle value lies beyond the limit too.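

Compound 4, which has the shortest chain shown, reads > 100000 nM in this assay, a limit of the assay and not a number. Placing hydroxycarbamoyl at this position gives an at least 1.0-fold higher number from compound 3 to compound 4 (0.01 log units; that floor lies within the scatter) and an at least 1.0-fold higher number from compound 1 to compound 4 (0.01 log units; that floor lies within the scatter), so shortening the chain shows no step beyond the scatter, and the step involving the two limits cannot be read. Repeating the change on a second pair settles little: the same change on two cores in this assay, an at least 1.0-fold higher number (0.01 log units; that floor lies within the scatter) from compound 1 to compound 2 and an at least 1.0-fold higher number (0.01 log units; that floor lies within the scatter) from compound 3 to compound 4; the limit leaves it open whether they differ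

Going by these compounds, how much activity, if any, the limits conceal remains open: the limit of > 100000 nM in this assay, at which 2 of the 4 values shown sit A longer chain, or a carboxylic acid in place of hydroxycarbamoyl, could show whether this end of the molecule affects the reading at all.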